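Moving the hydroxy group on the pendant phenyl ring of compound 2

This account rests on a few compounds, and the source may have more. Where it says the series, first, only, none or still open, it means among the compounds named here.

Compound 2 `COc1cc(N2C(N)=C(C#N)C(c3ccccc3O)C3=C2CC(C)(C)CC3=O)cc(OC)c1OC` stands lowest of the three measured compounds in a functional assay on Ehrlich cells (Mus musculus) for cytotoxicity, tested at 25 ug/mL (on this read-out higher numbers stand for a stronger effect at the one concentration tested and lower numbers for a weaker effect), giving 0%. Compound 1 `COc1cc(N2C(N)=C(C#N)C(c3ccc([N+](=O)[O-])cc3)C3=C2CC(C)(C)CC3=O)cc(OC)c1OC` gives 50% in this assay, and compound 3 `COc1cc(N2C(N)=C(C#N)C(c3ccccc3Cl)C3=C2CC(C)(C)CC3=O)cc(OC)c1OC` gives 15%. The step of a number 50 percentage points lower from compound 1 to compound 2 (beyond the scatter) and the step of a number 35 percentage points lower from compound 1 to compound 3 (beyond the scatter) are both large, while the step of a number 15 percentage points higher from compound 2 to compound 3 (beyond the scatter) is modest. Compound 4 `COc1cc(N2C(N)=C(C#N)C(c3ccc(O)cc3)C3=C2CC(C)(C)CC3=O)cc(OC)c1OC` differs from compound 2 by a rearrangement only: 4-hydroxyphenyl in place of 2-hydroxyphenyl on a saturated ring carbon. Within the data shown here, no measured pair differs solely in the position of a substituent on this phenyl ring, so the steps between compounds 1, 2 and 3 bear on the change only loosely: they show that changes on this ring can shift the number strongly, and that compound 1, the one compound carrying a group in the 4-position, gives the highest number. Because compound 2 gives 0%, the number can only stay or rise. Compound 4 is therefore expected to lie somewhat higher, with a step of a number 20 percentage points higher from compound 2 to compound 4 (beyond the scatter) that is uncertain in size. The estimate for compound 4 is 20%, between 0% and 50%.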

Compound 4, a percentage reported as activity, at one concentration (the size of the read-out at that concentration, not a potency): 20%
Compound 4: middle estimate and measured number agree at the digits printed, and the stated range covers the measured number.
By their numbers in this assay, from the lowest: compound 2; then compounds 3 and 4 (each within the scatter of the next); then compound 1.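

Moving the hydroxy group gives the first pair that differs only in where a substituent sits on this phenyl ring: in this assay, a number 20 percentage points higher from compound 2 to compound 4 (beyond the scatter), so the change from 2-hydroxyphenyl to 4-hydroxyphenyl alone is enough to move the number beyond the scatter. The rearrangement does not reach the level of the nitro compound, since a number 30 percentage points lower from compound 1 to compound 4 (beyond the scatter), which shows that the group itself also counts when 4-nitrophenyl and 4-hydroxyphenyl are compared, while a number 5 percentage points higher from compound 3 to compound 4 (within the scatter) leaves compound 3 and compound 4 without an order. Nothing available explains the effect of either change. As far as these compounds go, it remains open whether an amine or a carboxylic acid in place of the hydroxy on 4-hydroxyphenyl would come closer to compound 1, and whether the chloro group responds to the same rearrangement as the hydroxy group.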